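The source may hold more compounds than are shown below. What is called first, only, known or untested is meant among the compounds shown, and "the series" means these compounds.

In a functional assay on A-375 cells (Homo sapiens) for inhibition, read by MTT assay, with a stated time of 4 days (on this read-out higher numbers stand for weaker inhibition and lower numbers for stronger inhibition), compound 1 `Cc1cc(N2C[C@@H]3C[C@H]2CN3C)ccc1-c1ccnc2c(-c3cccc4[nH]ncc34)c(-c3ccncc3)nn12` gives 137 nM and compound 2 `CN1C[C@@H]2C[C@H]1CN2c1ccc(-c2ccnc3c(-c4ccc(F)c5[nH]ncc45)c(-c4ccncc4)nn23)cc1` gives 68 nM and these two values lie within the usual scatter of each other, so neither can be ranked above the other. Compound 3 `Cc1cc(N2C[C@@H]3C[C@H]2CN3C)ccc1-c1ccnc2c(-c3ccc(F)c4[nH]ncc34)c(-c3ccncc3)nn12` is compound 2 with methyl in place of hydrogen on an aromatic carbon and has not yet been measured. Among the compounds with values here, no pair of measured compounds shows this change alone, so in this assay no step beyond the scatter is expected, only perhaps a slight weakening. For compound 3 the estimated value is 90 nM with 35 nM to 230 nM as the expected range.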

Compound 3, half-maximal inhibitory concentration: 188 nM
Compound 3: middle estimate off by 2.1-fold (0.32 log units), on the low side; measured number inside the range.
By their numbers in this assay, from the lowest: compounds 2, 1 and 3 (each within the scatter of the next, the first and the last beyond it).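

In this assay, methyl in place of hydrogen on this aromatic carbon, ortho to a large group, gives a 2.8-fold higher number from compound 2 to compound 3 (0.44 log units; beyond the scatter), so even this single added carbon weakens inhibition here. Fluoro in place of hydrogen, with that methyl present, gives a 1.4-fold higher number from compound 1 to compound 3 (0.14 log units; within the scatter), so no effect of the fluoro can be read. No measurement shown here explains the methyl step. On these data alone, whether the methyl has the same effect without the fluoro remains open. So does what an ethyl, a methoxy or an amine would do on the same carbon.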